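The compounds below may be only part of what the source reports. "The series", "measured", "known", "first", "only" and "open" are said of these compounds alone.

Of the compounds shown here, three have been measured in a functional assay on ileum (Cavia porcellus) for inhibition; a higher number here means a weaker inhibitor, a lower number a stronger inhibitor. Compound 1 `CCOC(=O)C1=C(C)NC(C)=C(C(=O)OCC)C1c1c(-c2cc(OC)ccc2OC)nc2sccn12` gives 46 nM, compound 2 `COC(=O)C1=C(C)NC(C)=C(C(=O)OC)C1c1c(-c2ccsc2)nc2sccn12` gives 2.3 nM, and compound 3 `COC(=O)C1=C(C)NC(C)=C(C(=O)OC)C1c1c(-c2c(Cl)csc2Cl)nc2sc(C)cn12` gives 3230 nM, the highest of the three numbers and beyond the scatter of both others, so compound 3 is the weakest inhibitor measured. Compound 4 `COC(=O)C1=C(C)NC(C)=C(C(=O)OC)C1c1c(-c2cccs2)nc2sc(C)cn12` has not yet been tested. It differs from compound 3 in one place: a group of 5 heavy atoms (4 carbon, 1 sulfur; one five-membered aromatic ring with 1 hetero atom) in place of a group of 7 heavy atoms (4 carbon, 1 sulfur, 2 chlorine; one five-membered aromatic ring with 1 hetero atom), on an aromatic carbon. Among the compounds with values here, no pair of measured compounds differs in a single place, so no measured step shows what this change does on its own. Compound 2, which also lacks the two chlorines, gives 2.3 nM in this assay, and that points toward a much lower number. The expected step of a 160-fold lower number from compound 3 to compound 4 (2.21 log units; beyond the scatter) is a large fall. Compound 4 is estimated at 20 nM, with a range from 3 nM to 150 nM.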

Compound 4, half-maximal inhibitory concentration: 1370 nM
Beside the measured number, compound 4's estimate is 69-fold (1.84 log units) below it, outside the stated range (above it).
By their numbers in this assay, from the lowest: compound 2; then compound 1; then compound 4; then compound 3.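

In this assay, within the data shown here, putting thiophen-2-yl in place of the chlorine-bearing group on this aromatic carbon gives a 2.4-fold lower number from compound 3 to compound 4 (0.37 log units; beyond the scatter), the first step that isolates a change at this position. The step swaps the whole group, so it cannot separate the loss of the two chlorines from any other difference between the groups. Nothing measured here explains the size of this step. Still open, as far as these compounds go, is how a plain phenyl ring or an amine on this carbon would compare with thiophen-2-yl, with the rest of compound 4 unchanged.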